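A few compounds are considered here, and "the series" means these few. Any claim that something is new, unique, unknown or untested is made for them only; others in the source may bear on it.

Compound 1 `O=C1C(NC2CC2)=CC(=O)c2c1nc1n2[C@H]2OC[C@@H](O)[C@H]2OC1`, compound 2 `O=C1C=C(Nc2ccccc2)C(=O)c2c1nc1n2[C@H]2OC[C@@H](O)[C@H]2OC1` and compound 3 `O=C1C(Nc2ccc(Br)cc2)=CC(=O)c2c1nc1n2[C@H]2OC[C@@H](O)[C@H]2OC1` were measured in a functional assay on HeLa cells (Homo sapiens) for inhibition, read by sulforhodamine B assay; on this read-out lower numbers stand for stronger inhibition and higher numbers for weaker inhibition. Compound 1 gives > 16000 nM, which is a limit of the assay and not a number. Compound 2 gives 5620 nM. Compound 3 gives 5220 nM.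

Of the two numbers, compound 2 stands highest, with compound 3 within the scatter of it. Compound 4 `O=C1C=C(Nc2ccc(Br)cc2)C(=O)c2c1nc1n2[C@H]2OC[C@@H](O)[C@H]2OC1` differs from compound 2 by bromo in place of hydrogen on an aromatic carbon. Among the compounds with values here, only one measured step exists, an at least 3.0-fold lower number from compound 1 to compound 3 (0.48 log units; beyond the scatter), and it exchanges a cyclopropyl for a whole 4-bromophenyl, so it does not isolate the bromo. Compound 3, which also carries a 4-bromophenyl, sits within the scatter of compound 2. No step beyond the scatter is therefore expected in this assay. Compound 4 is expected at 5000 nM, with a range from 2000 nM to 12000 nM, which means an expected step of a 1.1-fold lower number from compound 2 to compound 4 (0.05 log units; within the scatter).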

Compound 4, half-maximal inhibitory concentration: 3830 nM
The estimate for compound 4 lay 1.3-fold (0.12 log units) above the measured number; measured number inside the range.
By their numbers in this assay, from the lowest: compounds 4, 3 and 2 (each within the scatter of the next). At a limit, above all of these: compound 1.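

Taken alone, bromo in place of hydrogen on the phenyl ring gives, in this assay (a 1.5-fold lower number from compound 2 to compound 4 (0.17 log units; within the scatter)), a step that the earlier exchange of a whole group could not isolate. At this place, para to a large group, the added bromine atom therefore makes no difference beyond the scatter. Nothing in the available evidence bears on this result.

Still open, from the compounds shown here alone, is whether another group at this place, such as methoxy, an amine or a carboxylic acid, would move the number beyond the scatter.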